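The compounds below may be only part of what the source reports. "The series", "measured", "known", "first", "only" and "open" are said of these compounds alone.

Measured so far:
- compound 1 `Cc1ccc(C(=O)Nc2ccc(C#N)cc2)c(O)c1`: 2420 nM
- compound 2 `N#Cc1ccc(NC(=O)c2ccc(-c3cccnc3)cc2O)cc1`: 6660 nM
- compound 3 `COc1cccc(C(=O)Nc2ccc(C#N)cc2)c1O`: > 10000 nM

In a functional assay on HL-60 cells (Homo sapiens) for cytotoxicity, read by luminescence and CellTiter-Glo, with a stated time of 3 days (on this read-out higher numbers stand for weaker inhibition and lower numbers for stronger inhibition), compound 3 stands only at a limit of the assay, not a number, sitting at the limit of > 10000 nM in this assay, at which 1 of the 3 values shown sits. Compound 4 `N#Cc1ccc(NC(=O)c2ccccc2O)cc1` differs from compound 3 by hydrogen in place of methoxy on an aromatic carbon. Going by the values given here, the one measured step, a 2.8-fold higher number from compound 1 to compound 2 (0.44 log units; beyond the scatter), concerns a different group at a different place and gives no direct guide to removing a methoxy ortho to a hydroxy group. Compound 1 and compound 2 show where the core without this methoxy can land. Compound 4 is therefore expected near that range, estimated at 4000 nM (1500 nM to 12000 nM). This expectation means an at least 2.5-fold lower number from compound 3 to compound 4 (0.39 log units; beyond the scatter), a direction that cannot be fixed while compound 3 is only a limit.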

Compound 4, half-maximal inhibitory concentration: 4620 nM
Estimate against measurement, compound 4: 1.2-fold (0.06 log units) below; the range from low to high includes it.
By their numbers in this assay, from the lowest: compounds 1, 4 and 2 (each within the scatter of the next, the first and the last beyond it). At a limit, above all of these: compound 3.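

In this assay compound 3 gives only a limit, not a number: the limit of > 10000 nM in this assay, at which 1 of the 4 values shown sits.

Hydrogen in place of methoxy, ortho to a hydroxy group, gives an at least 2.1-fold lower number from compound 3 to compound 4 (0.33 log units; beyond the scatter), so a measurable number returns at this position once methoxy leaves. On the other position, hydrogen does not separate from either group there, with a 1.4-fold lower number from compound 2 to compound 4 (0.16 log units; within the scatter) and a 1.9-fold higher number from compound 1 to compound 4 (0.28 log units; within the scatter).

Going by these compounds, the true size of the methoxy step stays open while compound 3 remains a limit. On these data alone, whether only methoxy has this effect at this position also stays open, and a fluorine or an amine there would test it.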